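From 4-chlorophenyl to 3-fluorophenyl on the amide

This account rests on a few compounds, and the source may have more. Where it says the series, first, only, none or still open, it means among the compounds named here.

In a functional assay on A549 cells (Homo sapiens) for inhibition, read by CCK-8 assay, with a stated time of 72 h, tested at 10 uM (on this read-out lower numbers stand for less inhibition of growth and higher numbers for more inhibition of growth at the one concentration tested), compound 1 `CN(C)C(=O)c1cc2cnc(Nc3ccc(NC(=O)C4(C(=O)Nc5ccc(F)cc5)CC4)cc3)nc2n1C1CCCC1` gives 102%, and compound 2 `CN(C)C(=O)c1cc2cnc(Nc3ccc(NC(=O)C4(C(=O)Nc5ccc(Cl)cc5)CC4)cc3)nc2n1C1CCCC1` gives 101%. These two values match within the scatter, so compound 2 cannot be ranked against compound 1.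

Compound 3 `CN(C)C(=O)c1cc2cnc(Nc3ccc(NC(=O)C4(C(=O)Nc5cccc(F)c5)CC4)cc3)nc2n1C1CCCC1` keeps the shared core and differs from compound 2 in one place: 3-fluorophenyl in place of 4-chlorophenyl on an amide-type nitrogen. Here, 3-fluorophenyl takes the place of 4-chlorophenyl on an amide-type nitrogen. Within the data shown here, the only measured step that bears on this is a number 1 percentage points lower from compound 1 to compound 2 (within the scatter), where chloro replaces fluoro on an aromatic carbon. Among the measured compounds shown here, no measured compound carries the 3-fluorophenyl group, so that step covers only part of the change. The estimated change in this assay is a number 4 percentage points lower from compound 2 to compound 3 (within the scatter), which means no expected shift beyond the scatter. Compound 3 is expected at 97%, with an estimated range of 80% to 106%.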

Compound 3, percent growth inhibition at one concentration: 91.8%
Beside the measured number, compound 3's estimate is 5.2 percentage points above it; low and high end bracket the measured number.
By their numbers in this assay, from the lowest: compounds 3, 2 and 1 (each within the scatter of the next, the first and the last beyond it).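

Until now, 4-fluorophenyl and 4-chlorophenyl on this amide-type nitrogen could not be told apart in this assay, so the position had shown no response to a change of its group. Among these compounds, replacing 4-fluorophenyl with 3-fluorophenyl gives a number 10.2 percentage points lower from compound 1 to compound 3 (beyond the scatter) as the first step beyond the scatter in this set, and it is a modest one, with fluorine kept and only its place on the ring changed. Replacing 4-chlorophenyl with 3-fluorophenyl gives a number 9.2 percentage points lower from compound 2 to compound 3 (within the scatter) and so does not separate that pair.

No evidence at hand explains the shift.
Going by these compounds, whether 3-chlorophenyl or an unsubstituted phenyl would sit with compound 3 or with compound 1 remains open, as does the outcome of placing an amine or a carboxylic acid on this ring.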